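Tertiary Amine Side Chains on a Shared Core

This account rests on a few compounds, and the source may have more. Where it says the series, first, only, none or still open, it means among the compounds named here.

Measured compounds:
- compound 1, `c1coc(CNc2nc(NCCCN3CCCC3)nc3ccccc23)c1`, gives 40.1%
- compound 2, `Clc1cccc(N2CCN(CCCCNc3nc(NCc4ccco4)c4ccccc4n3)CC2)c1Cl`, gives 94.3%
- compound 3, `Fc1ccc2nc(NCCN3CCN(c4cccc(Cl)c4Cl)CC3)nc(NCc3ccco3)c2c1`, gives "not determined" (no result reported)

The series is read in a functional assay on DU-145 cells (Homo sapiens) for cytotoxicity, read by MTT assay, with a stated time of 2 days, tested at 10 uM; a higher number here means more inhibition at the concentration tested (going by the name of the read-out), a lower number less inhibition. Compound 1 stands lowest of the two numbers reported; the nearest entry is compound 2, whose value lies higher by a margin beyond the usual scatter, while compound 3 contributes no single number.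

The step from compound 1 to compound 4, `CCN(CC)CCNc1nc(NCc2ccco2)c2ccccc2n1`, is a change of the side chain: diethylamino in place of (pyrrolidin-1-yl)methyl on a saturated chain carbon, two bonds along the chain from a nitrogen on an aromatic ring. The chain is shortened and the five-membered non-aromatic ring is opened, yet the single hydrogen-bond acceptor remains and there is still no charge. Among the compounds with values here, no measured pair in this set shows such a change, so its size must be guessed from compound 1 alone.

A small step is expected, within the scatter, with no clear direction, and the estimated step of a number 4.1 percentage points lower from compound 1 to compound 4 (within the scatter) reflects that. For compound 4 the expected value is 36%, with a range from 15% to 60%.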

Compound 4, a percentage reported as inhibition, at one concentration (the size of the read-out at that concentration, not a potency): 28.5%
Compound 4: middle estimate off by 7.5 percentage points, on the high side; low and high end bracket the measured number.
By their numbers in this assay, from the lowest: compound 4; then compound 1; then compound 2.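

In this assay, within the data shown here, this is the first comparison that differs in one place: diethylamino replaces (pyrrolidin-1-yl)methyl on a saturated chain carbon, two bonds along the chain from a nitrogen on an aromatic ring, and the change gives a number 11.6 percentage points lower from compound 1 to compound 4 (beyond the scatter) in this pair. It shows that the read-out responds at this position even though the counts of hydrogen-bond donors and acceptors and the net charge stay the same on both sides. No measurement available here accounts for the step.

The compounds shown leave open whether a piperidine or a morpholine in this place, or a longer chain carrying the diethylamino group, would move the read-out in the same direction. One pair also cannot show whether the same exchange would give a similar step on a different core.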